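This account rests on a few compounds, and the source may have more. Where it says the series, first, only, none or still open, it means among the compounds named here.

Three compounds of this set have been run through a functional assay on the whole organism (strain albino) for inhibition, with Rattus norvegicus as the target, read by paw edema, with stated times of 30 min and 2 h, at a dose of 25 mg/kg by the intraperitoneal route; on this read-out lower numbers stand for less inhibition and higher numbers for more inhibition at the one dose given (going by the name of the read-out). Compound 3 `COc1ccc(C2=NN(C(=O)NS(=O)(=O)c3ccc(C)cc3)CC2C)c(OC)c1` gives 27.3%. Compound 1 `COc1ccc(C2=NN(C(=O)NS(=O)(=O)c3ccc(C)cc3)CC2c2ccccc2)c(OC)c1` gives 6.33%, and compound 2 `COc1ccc(C2=NN(C(=S)NC(=O)c3ccc(Cl)cc3)CC2C)c(OC)c1` gives 0%, a number that sits within the scatter of compound 1 and beyond it from compound 3. Compound 3 and compound 1 differ in one place, (phenyl in place of methyl on a saturated ring carbon), and the step of a number 21 percentage points lower from compound 3 to compound 1 (beyond the scatter). Compound 4 `COc1ccc(C2=NN(C(=S)NC(=O)c3ccc(Cl)cc3)CC2c2ccccc2)c(OC)c1` has not yet been measured in this assay. It stands to compound 2 as compound 1 stands to compound 3, carrying the same change, (phenyl in place of methyl on a saturated ring carbon). How the core of compound 2 differs from the core of compound 3 is not broken down here. For compound 4 the expected step is a number 2 percentage points higher from compound 2 to compound 4 (within the scatter), which rests on the earlier step of a number 21 percentage points lower from compound 3 to compound 1 (beyond the scatter) that pulled inhibition down, and on compound 2 already standing at 0%, the bottom of the read-out, so that no further fall can be registered. Compound 4 is accordingly expected to show about 2% in this assay, somewhere between 0% and 12%.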

Compound 4, a percentage reported as inhibition, in the whole organism at one dose (the size of the read-out at that dose, not a potency): 0%
Compound 4: middle estimate off by 2 percentage points, on the high side; the range from low to high includes it.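

For phenyl in place of methyl on a saturated ring carbon, this assay now shows no change at the digits printed from compound 2 to compound 4 (within the scatter). Set beside the earlier step, the same change does not read the same on the two cores: the same change on two cores in this assay, a number 21 percentage points lower (beyond the scatter) from compound 3 to compound 1 and no change at the digits printed (within the scatter) from compound 2 to compound 4, 21 percentage points apart, beyond the scatter of two such steps This does not show that the core of compound 2 is indifferent to the change: compound 2 and compound 4 both stand at the bottom of the read-out, where no fall can register, and the step on that core cannot tell whether phenyl would lower inhibition there as well.

The compounds shown leave open how another group on that saturated ring carbon, such as an ethyl or a benzyl, would read on either core. Also open, from the compounds shown here alone, is whether phenyl in place of methyl would lower inhibition on a further core that starts well above the bottom of the read-out.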